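Swapping fluorine for dimethylamino on the pyridine ring

The source may hold more compounds than are shown below. What is called first, only, known or untested is meant among the compounds shown, and "the series" means these compounds.

The two measured compounds share a core and differ only in one small group on a pyridine ring. Compound 1 `O=C(O)Cc1sc(C(c2ccc(F)cc2)c2ccc(F)cc2)nc1-c1ccncc1` gives 5.3 nM in an in vitro assay on HEK385-7 cells for displacement of a labelled ligand from prostaglandin D2 receptor 2 (Homo sapiens); on this read-out lower numbers stand for stronger inhibition and higher numbers for weaker inhibition. Compound 2 `O=C(O)Cc1sc(C(c2ccc(F)cc2)c2ccc(F)cc2)nc1-c1ccnc(F)c1` carries a fluoro in place of hydrogen on an aromatic carbon, and in this assay compound 2 gives 0.48 nM. The step of an 11-fold lower number from compound 1 to compound 2 (1.04 log units; beyond the scatter) shows that this position responds strongly to substitution. On the numbers shown, compound 2 has the lowest value of the two, with compound 1 as its only neighbour.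

Compound 3 `CN(C)c1cc(-c2nc(C(c3ccc(F)cc3)c3ccc(F)cc3)sc2CC(=O)O)ccn1` is not yet measured. It differs from compound 2 by dimethylamino in place of fluoro on an aromatic carbon. For the measured compounds named here, the only step that bears on this change is the one from compound 1 to compound 2, which was large; it tells that a small group next to the ring nitrogen helps, but nothing about a group of this size and shape, so the expectation is less certain. Compound 3 is expected to land between its two neighbours, with an estimated 3.1-fold higher number from compound 2 to compound 3 (0.49 log units; beyond the scatter) in this assay, giving an expected value of 1.5 nM, within a range from 0.3 nM to 8 nM.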

Compound 3, half-maximal inhibitory concentration: 380 nM
Compound 3: middle estimate off by 250-fold (2.40 log units), on the low side, outside the stated range (above it).
By their numbers in this assay, from the lowest: compound 2; then compound 1; then compound 3.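

The position next to the ring nitrogen does not simply reward any added group, as the fluoro result alone might have suggested. Dimethylamino in place of fluoro gives a 790-fold higher number from compound 2 to compound 3 (2.90 log units; beyond the scatter) in this assay, so the same ring carbon can carry either the best or the worst of the three groups seen so far. Hydrogen in the same place gives a direct comparison: adding dimethylamino gives a 72-fold higher number from compound 1 to compound 3 (1.86 log units; beyond the scatter), which shows that this group does more than lose the gain seen with fluoro, since compound 3 also falls well behind the compound with nothing added there. No measurement shown here explains why these groups differ so sharply.

The compounds shown cover only hydrogen, fluoro and dimethylamino at this position, so it remains open how the numbers change across other groups, such as chloro, methyl, methoxy or a plain amino group. Methylamino, with one methyl fewer on the nitrogen than dimethylamino, would help to show whether the large loss extends to simpler amines or belongs to dimethylamino alone.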